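A few compounds are considered here, and "the series" means these few. Any claim that something is new, unique, unknown or untested is made for them only; others in the source may bear on it.

Among the compounds with values here, compound 3, `CC(C)Cc1cc2oc(=O)n(CCC(=O)O)c2cc1Cl`, stands second highest of the three numbers measured so far in an assay on HEK293 cells for inhibition of kynurenine 3-monooxygenase (Homo sapiens), read by LC-MS, with a stated time of 20 h (a lower number here means a stronger inhibitor, a higher number a weaker inhibitor), with compound 3 giving 794 nM. Its nearest neighbour is compound 1, `CCc1cc2oc(=O)n(CCC(=O)O)c2cc1Cl`, for which compound 1 gives 316 nM; the furthest is compound 2, `O=C(O)CCn1c(=O)oc2cc(Cl)c(Cl)cc21`, for which compound 2 gives 2000 nM. The step from compound 3 to compound 4, `CCOc1cc2oc(=O)n(CCC(=O)O)c2cc1Cl`, is ethoxy in place of isobutyl on an aromatic carbon. Within the data shown here, two measured steps touch the isobutyl group that leaves: there was a 2.5-fold higher number from compound 1 to compound 3 (0.40 log units; beyond the scatter), and there was a 2.5-fold lower number from compound 2 to compound 3 (0.40 log units; beyond the scatter). Among the measured compounds shown here, both are modest, and neither involves an oxygen-linked group, so no measured step shows what ethoxy itself does. Since the isobutyl group is removed, the author expects the step to go roughly back toward the number of compound 1, a change that is a 2.0-fold lower number from compound 3 to compound 4 (0.30 log units; within the scatter) in this assay. Compound 4 is therefore estimated at 400 nM, in a range from 130 nM to 1250 nM.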

Compound 4, half-maximal inhibitory concentration: 398 nM
Estimate against measurement, compound 4: 1.0-fold (0.00 log units) above; the measured number falls inside the stated range.
By their numbers in this assay, from the lowest: compounds 1, 4 and 3 (each within the scatter of the next, the first and the last beyond it); then compound 2.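

In this assay, within the data shown here, an oxygen-linked group at this aromatic carbon, ortho to a chloro group, separates from chloro as the carbon-linked groups do, with a 5.0-fold lower number from compound 2 to compound 4 (0.70 log units; beyond the scatter) beyond what the earlier steps could say about ethoxy. Ethoxy cannot be told apart from either carbon-linked group, since a 1.3-fold higher number from compound 1 to compound 4 (0.10 log units; within the scatter) and a 2.0-fold lower number from compound 3 to compound 4 (0.30 log units; within the scatter) both leave compound 4 within the scatter of its neighbours, even though compound 1 and compound 3 differ from each other beyond it; placing an oxygen on this carbon therefore brings no clear change in this series. Nothing available explains these results.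

The compounds shown leave open how a methoxy group, a longer chain such as butoxy, or an amine would behave at this carbon. They also leave open whether ethoxy would give the same result if the chloro group were replaced by fluoro.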